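This account rests on a few compounds, and the source may have more. Where it says the series, first, only, none or still open, it means among the compounds named here.

Measured compounds:
Compound 1, `CCN(CC)Cc1cc(-c2ccc(Cl)cc2)n(Nc2ccnc3cc(Cl)ccc23)c1C`: 5810 nM
Compound 2, `Cc1c(CN2CCCC2)cc(-c2ccc(Cl)cc2)n1Nc1ccnc2cc(Cl)ccc12`: 7180 nM

Both compounds were tested in an ADME assay on HMEC-1 cells (Homo sapiens) for cytotoxicity, read by MTT assay, with a stated time of 72 h; a higher number here means that more compound is tolerated, a lower number that less compound is tolerated. They share one core and differ only in the amine attached to the saturated chain carbon; the step of a 1.2-fold higher number from compound 1 to compound 2 (0.09 log units; within the scatter) shows that this exchange leaves the tolerated concentration unchanged within the scatter. Compound 2 therefore stands beside compound 1, with no order between the two that the numbers could support.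

Compound 3, `Cc1c(CN2CCCC2)cc(-c2ccc(C(F)(F)F)cc2)n1Nc1ccnc2cc(Cl)ccc12`, is the next compound, not yet measured in this assay. It is made from compound 2 by the change (trifluoromethyl in place of chloro on an aromatic carbon). For the measured compounds named here, no measured step bears on this kind of change: the only step seen so far touches the amine on the saturated chain carbon, not the six-membered carbon ring that carries the chloro group. With nothing in the data pointing in either direction, the expectation for this assay is a step of no more than the scatter from compound 2 to compound 3, a 1.0-fold lower number from compound 2 to compound 3 (0.01 log units; within the scatter). Compound 3 is accordingly estimated at 7000 nM, with a range from 3000 nM to 16000 nM.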

Compound 3, half-maximal cytotoxic concentration: 4700 nM
Beside the measured number, compound 3's estimate is 1.5-fold (0.17 log units) above it; the range from low to high includes it.
By their numbers in this assay, from the lowest: compounds 3, 1 and 2 (each within the scatter of the next).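

In this assay, for the compounds shown here, the exchange of 4-chlorophenyl for 4-(trifluoromethyl)phenyl gives a 1.5-fold lower number from compound 2 to compound 3 (0.18 log units; within the scatter) and is the first reading at this place, on the six-membered aromatic ring of carbon only rather than at the amine. Although a single chlorine gives way to a group of four heavy atoms, the tolerated concentration stays within the scatter, so this exchange does not separate the two compounds. Together with the earlier exchange of the amine, this means that two different places on the shared core have each been varied once, and neither step separates the compounds; no measurement at hand says what lies behind this result.

The compounds shown leave open whether a quite different group at this place, such as a methoxy group, a nitrile or a carboxylic acid, would give a step beyond the scatter. They also leave open whether the same exchange of chloro for trifluoromethyl would read the same way with the diethylamino group of compound 1, or with a morpholine in place of the pyrrolidine.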